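The compounds below may be only part of what the source reports. "The series", "measured", "known", "first", "only" and "open" are said of these compounds alone.

Compound 3 `C[C@H](NC(=O)Nc1ccccc1C(C)(C)C)c1ccccc1` carries the tert-butyl member of the shared core. In an ADME assay on the whole organism with Oryza sativa as the target, tested at 0.1 uM (on this read-out higher numbers stand for a weaker effect at the one concentration tested and lower numbers for a stronger effect), compound 3 gives 101%. Compound 1 `CCc1ccccc1NC(=O)N[C@@H](C)c1ccccc1` gives 100% in this assay, and compound 2 `CC(C)c1ccccc1NC(=O)N[C@@H](C)c1ccccc1` gives 99%. Compound 3 holds the highest of the three numbers, yet a number 1 percentage points higher from compound 1 to compound 3 (within the scatter) and a number 2 percentage points higher from compound 2 to compound 3 (within the scatter) both fall within the scatter, as does a number 1 percentage points lower from compound 1 to compound 2 (within the scatter). Compound 4 `C[C@H](NC(=O)Nc1ccccc1C(F)(F)F)c1ccccc1` differs from compound 3 by trifluoromethyl in place of tert-butyl on an aromatic carbon. Going by the values given here, no measured step introduces trifluoromethyl, so none bears directly on this change; the one measured step at the same aromatic carbon, a number 1 percentage points higher from compound 1 to compound 3 (within the scatter), stayed within the scatter. The expected step is therefore a number 3 percentage points lower from compound 3 to compound 4 (within the scatter), nothing beyond the scatter. Compound 4 is estimated at 98%, with a range from 85% to 105%.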

Compound 4, a percentage reported as activity, at one concentration (the size of the read-out at that concentration, not a potency): 97%
The estimate for compound 4 lay 1 percentage points above the measured number, within the range that was stated.
By their numbers in this assay, from the lowest: compounds 4, 2, 1 and 3 (each within the scatter of the next).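

Trifluoromethyl, the first group here with no alkyl hydrogens, replaces tert-butyl with a number 4 percentage points lower from compound 3 to compound 4 (within the scatter) in this assay at this aromatic carbon. The same exchange for isopropyl gives a number 2 percentage points lower from compound 2 to compound 4 (within the scatter) and for ethyl gives a number 3 percentage points lower from compound 1 to compound 4 (within the scatter), so fluorine-bearing and alkyl groups at this position cannot be told apart on this read-out. No further data explain this flat result.

Open, on these data alone, is whether an amine, a carboxylic acid or a plain hydrogen at this aromatic carbon would separate from these four compounds. Substitution elsewhere on the shared core also remains open.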